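Swapping the amide end of the acyl chain

The compounds below may be only part of what the source reports. "The series", "measured", "known", "first", "only" and "open" are said of these compounds alone.

Values in an ADME assay on CCRF-CEM cells (Homo sapiens) for cytotoxicity, with a stated time of 4 days; a higher number here means that more compound is tolerated, a lower number that less compound is tolerated:
compound 1 `Cc1cn([C@@H]2O[C@H](CO[Si](C)(C)C(C)(C)C)[C@@]3(OS(=O)(=O)C=C3N)[C@H]2O[Si](C)(C)C(C)(C)C)c(=O)n(C(=O)C2CC2)c1=O`: 11000 nM
compound 2 `Cc1cn([C@@H]2O[C@H](CO[Si](C)(C)C(C)(C)C)[C@@]3(OS(=O)(=O)C=C3N)[C@H]2O[Si](C)(C)C(C)(C)C)c(=O)n(C(=O)CCCC(N)=O)c1=O`: 8700 nM
compound 3 `CNC(=O)CCCC(=O)n1c(=O)c(C)cn([C@@H]2O[C@H](CO[Si](C)(C)C(C)(C)C)[C@@]3(OS(=O)(=O)C=C3N)[C@H]2O[Si](C)(C)C(C)(C)C)c1=O`: 9100 nM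

Compound 3, at 9100 nM, stands within the scatter of both other compounds, so the three values show no order. The next structure is compound 4 `CSC(=O)CCCC(=O)n1c(=O)c(C)cn([C@@H]2O[C@H](CO[Si](C)(C)C(C)(C)C)[C@@]3(OS(=O)(=O)C=C3N)[C@H]2O[Si](C)(C)C(C)(C)C)c1=O`, which has methylsulfanyl in place of methylamino on a carbonyl carbon.

Going by the values given here, no measured compound carries this methylsulfanyl group, so the available steps give only indirect guidance. The closest measured change, methyl in place of hydrogen on an amide-type nitrogen, gave a 1.0-fold higher number from compound 2 to compound 3 (0.02 log units; within the scatter). Larger replacements of the group on the carbonyl carbon gave a 1.3-fold lower number from compound 1 to compound 2 (0.10 log units; within the scatter) and a 1.2-fold lower number from compound 1 to compound 3 (0.08 log units; within the scatter). All three steps lie within the scatter, and even the exchange of cyclopropyl for the longer chains did not move the number beyond it. On that basis, no step beyond the scatter is expected in this assay, and no direction can be favoured. The estimated step is a 1.0-fold lower number from compound 3 to compound 4 (0.00 log units; within the scatter). For compound 4 the expected value is 9000 nM, with an estimated range of 5000 nM to 16000 nM.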

Compound 4, half-maximal cytotoxic concentration: 9900 nM
Compound 4: the middle estimate sits 1.1-fold (0.04 log units) below what was measured; low and high end bracket the measured number.
By their numbers in this assay, from the lowest: compounds 2, 3, 4 and 1 (each within the scatter of the next).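

In this assay, replacing methylamino with methylsulfanyl changes the atom bound to a carbonyl carbon whose other neighbour is a saturated chain carbon from nitrogen to sulfur and removes the hydrogen-bond donor of methylamino, yet it gives a 1.1-fold higher number from compound 3 to compound 4 (0.04 log units; within the scatter). The new compound also stays level with the other two, with a 1.1-fold higher number from compound 2 to compound 4 (0.06 log units; within the scatter) for methylsulfanyl in place of amino and a 1.1-fold lower number from compound 1 to compound 4 (0.05 log units; within the scatter) for 3-((methylsulfanyl)carbonyl)propyl in place of cyclopropyl. Among these compounds, therefore, an amide nitrogen at the end of the chain is not required for the number to remain in this range, and the series now spans amino, methylamino, methylsulfanyl and the shorter cyclopropyl group without a step beyond the scatter. No accompanying measurement offers an explanation for this flat result.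

On these data alone, it remains open whether a carboxylic acid or a methoxy group in place of methylsulfanyl on the same carbonyl carbon would give a step beyond the scatter. A longer chain between the two carbonyl groups, or a basic amine at its end, is equally untested by the compounds shown here.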